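Swapping an aryl ketone substituent on a pyrazolyl enone

This account rests on a few compounds, and the source may have more. Where it says the series, first, only, none or still open, it means among the compounds named here.

Measured compounds:
- compound 1, `COc1ccc(-c2cc(/C=C/C(=O)c3ccc(N)cc3)[nH]n2)cc1OC`: 106% in a functional assay on OVCAR-3 cells (Homo sapiens) for cytotoxicity, read by sulforhodamine B assay, with a stated time of 48 h, tested at 0.01 uM; on this read-out higher numbers stand for a weaker effect at the one concentration tested and lower numbers for a stronger effect
- compound 2, `COc1ccc(C(=O)/C=C/c2cc(-c3cc(OC)c(OC)c(OC)c3)n[nH]2)cc1`: 101% in this assay

In this assay compound 2 gives 101%, and in the same assay compound 1 gives 106%. The two numbers lie within the usual scatter of each other, so neither compound can be called the stronger or the weaker of the pair; both read-outs sit at the level that means essentially no effect at the single concentration tested.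

Compound 3, `COc1cc(-c2cc(/C=C/C(=O)c3ccc(F)c(F)c3)[nH]n2)cc(OC)c1OC`, has not yet been measured in this assay. Its difference from compound 2 is 3,4-difluorophenyl in place of 4-methoxyphenyl on a carbonyl carbon. For the measured compounds named here, no step between two measured compounds is known here, so nothing in the data shows what this change does to the read-out. Given that compound 2 and compound 1 both sit near the no-effect level, the step from compound 2 to compound 3 is expected to be a number 1 percentage points lower from compound 2 to compound 3 (within the scatter), which is no step beyond the scatter in either direction. Compound 3 is therefore expected to give about 100% in this assay, within a range from 85% to 115%.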

Compound 3, a percentage reported as activity, at one concentration (the size of the read-out at that concentration, not a potency): 102%
Beside the measured number, compound 3's estimate is 2 percentage points below it; the range from low to high includes it.
By their numbers in this assay, from the lowest: compounds 2, 3 and 1 (each within the scatter of the next).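

In this assay, for the compounds shown here, the step of a number 1 percentage points higher from compound 2 to compound 3 (within the scatter) is the first that can be read at this place, on a carbonyl carbon whose other neighbours are: double-bonded chain carbon. Compound 2 and compound 3 cannot be told apart on this read-out, so 3,4-difluorophenyl and 4-methoxyphenyl, which differ in their heavy atoms and in the hydrogen-bond acceptor that only 4-methoxyphenyl carries, give the same picture at the one concentration tested, with both compounds at the level of essentially no effect. Going by these compounds alone, since that level leaves little room to separate two compounds, this shows only that the exchange produces no visible effect here, not that the position is indifferent to substitution, and no measurement is at hand that would offer an explanation for the result.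

On these data alone, what remains open is whether any group on this carbonyl carbon, such as a carboxylic acid, a dimethylamino group on the phenyl ring or a plain methyl in place of the aryl ring, would move the read-out away from the no-effect level. As far as these compounds go, it is also open whether compound 2 and compound 3 would separate at a higher concentration.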